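A few compounds are considered here, and "the series" means these few. Any claim that something is new, unique, unknown or untested is made for them only; others in the source may bear on it.

Measured compounds in an assay on HL-60 cells for agonist activity at vitamin D3 receptor (Homo sapiens), read by microscopy, with a stated time of 96 h; on this read-out lower numbers stand for an effect already at smaller amounts and higher numbers for an effect only at larger amounts of compound:
compound 1, `CCn1c(C(=O)NCCCN(C)C)ccc1C(CC)(CC)c1ccc(OCC(=O)C(C)(C)C)c(C)c1`, where compound 1 gives 96 nM
compound 2, `C#CCCOC(=O)c1ccc(C(CC)(CC)c2ccc(OCC(=O)C(C)(C)C)c(C)c2)n1CC`, where compound 2 gives 28800 nM
compound 3, `CCn1c(C(=O)NCCCN(C)C)ccc1C(CC)(CC)c1ccc(OCC(O)C(C)(C)C)c(C)c1`, where compound 3 gives 37 nM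

Compound 3 stands with the lowest of these three numbers: a 2.6-fold lower number from compound 1 to compound 3 (0.41 log units; beyond the scatter), and the gap to compound 2 is far wider. Compound 4, `CCn1c(C(=O)N(CCC#N)CCC#N)ccc1C(CC)(CC)c1ccc(OCC(O)C(C)(C)C)c(C)c1`, differs from compound 3 in one place: a group of 9 heavy atoms (6 carbon, 3 nitrogen; no ring) in place of a group of 7 heavy atoms (5 carbon, 2 nitrogen; no ring), on a carbonyl carbon. Among the measured compounds shown here, one measured step bears on this, because the same group left the carbonyl carbon there: a 300-fold higher number from compound 1 to compound 2 (2.48 log units; beyond the scatter), a large rise. For the measured compounds named here, the group entering compound 4 is not the one that entered compound 2, so that step cannot be copied directly, but both changes remove the (3-(dimethylamino)propyl)amino group, and no measured compound shows that group replaced without a marked loss. A higher number is therefore expected, though a smaller rise than from compound 1 to compound 2 is judged more likely than an equal one. Compound 4 is estimated at 1200 nM, with a range from 150 nM to 10000 nM. That estimate means an expected step of a 32-fold higher number from compound 3 to compound 4 (1.51 log units; beyond the scatter).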

Compound 4, half-maximal effective concentration: 97 nM
Compound 4: the middle estimate sits 12-fold (1.09 log units) above what was measured, outside the stated range (below it).
By their numbers in this assay, from the lowest: compound 3; then compounds 1 and 4 (each within the scatter of the next); then compound 2.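

In this assay, among the compounds shown here, the (3-(dimethylamino)propyl)amino group on the carbonyl carbon can give way to a larger group with no hydrogen-bond donor at only a modest cost, a 2.6-fold higher number from compound 3 to compound 4 (0.42 log units; beyond the scatter), so this position tolerates more than the earlier compounds suggested. The large rise seen when the same group left in the other swap, a 300-fold higher number from compound 1 to compound 2 (2.48 log units; beyond the scatter), therefore does not follow from losing that group alone; what enters matters too, at least across these two pairs, which also differ in the chain bound to the aromatic oxygen. Nothing given here explains the difference between these two steps.

Still open, as far as these compounds go, is how a simple amine such as dimethylamino or a carboxylic acid on the carbonyl carbon would behave. Also open, from the compounds shown here alone, is whether a shorter chain ending in a single nitrile would fare as well as the group in compound 4.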